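Triazolylmethyl spiro series: aryl swap at the triazole nitrogen

The compounds below may be only part of what the source reports. "The series", "measured", "known", "first", "only" and "open" are said of these compounds alone.

Measured so far in a functional assay on HCT-116 cells (Homo sapiens) for antiproliferative activity, read by MTT assay, with a stated time of 48 h; a higher number here means a weaker inhibitor, a lower number a stronger inhibitor:
compound 1 `N#CC1=C(N)Oc2c(N)cc3nc4ccccc4nc3c2C12C(=O)N(Cc1cnnn1-c1cccc(Br)c1)c1ccccc12`, 26100 nM
compound 2 `Cc1ccc(C)c(-n2nncc2CN2C(=O)C3(C(C#N)=C(N)Oc4c(N)cc5nc6ccccc6nc5c43)c3ccccc32)c1`, a limit of the assay, > 50000 nM
compound 3 `CCc1cccc(CC)c1-n1nncc1CN1C(=O)C2(C(C#N)=C(N)Oc3c(N)cc4nc5ccccc5nc4c32)c2ccccc21`, 37600 nM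

Compound 3 holds the highest of the two numbers given; its nearest neighbour is compound 1, and the gap a 1.4-fold higher number from compound 1 to compound 3 (0.16 log units; within the scatter) lies within the scatter. Compound 2 is reported only as a limit, and the two values on display together with it do not separate the three aryl groups from one another; see (the limit of > 50000 nM in this assay, at which 1 of the 3 values shown sits). Both steps that change the aryl group on the triazole nitrogen, an at least 1.9-fold higher number from compound 1 to compound 2 (0.28 log units; that floor lies within the scatter) and an at least 1.3-fold lower number from compound 2 to compound 3 (0.12 log units; that floor lies within the scatter), stay inside the scatter or reach only a floor that does.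

Compound 4 `Cc1ccc(Cl)cc1-n1nncc1CN1C(=O)C2(C(C#N)=C(N)Oc3c(N)cc4nc5ccccc5nc4c32)c2ccccc21` carries the change (5-chloro-2-methylphenyl in place of 2,6-diethylphenyl on an aromatic nitrogen). The measured steps that bear on it are the aryl swaps above: none of them moved the number beyond the scatter, and the 2,5-dimethylphenyl analogue compound 2 came back only as a limit. For compound 4 the step of a 1.1-fold higher number from compound 3 to compound 4 (0.03 log units; within the scatter) is therefore expected to stay within the scatter, with a fair chance that the assay again returns only a limit. Compound 4 is estimated at 40000 nM, between 15000 nM and 100000 nM.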

Compound 4, half-maximal inhibitory concentration: 37200 nM
The estimate for compound 4 lay 1.1-fold (0.03 log units) above the measured number, and the stated range covers the measured number.
By their numbers in this assay, from the lowest: compounds 1, 4 and 3 (each within the scatter of the next). At a limit, above all of these: compound 2.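

In this assay, 5-chloro-2-methylphenyl on the aromatic nitrogen leaves the number where 2,6-diethylphenyl had it (a 1.0-fold lower number from compound 3 to compound 4 (0.00 log units; within the scatter)), so exchanging the all-carbon aryl group for one that carries chlorine has no measurable effect here. The 3-bromophenyl analogue also cannot be told apart from compound 4 (a 1.4-fold higher number from compound 1 to compound 4 (0.15 log units; within the scatter)), which extends the flat picture to two aryl groups with different halogens and different substitution, and gives compounds 1, 3 and 4 a shared level in this assay. Within the data shown here, the one step that changes only chloro for methyl (an at least 1.3-fold lower number from compound 2 to compound 4 (0.12 log units; that floor lies within the scatter)) rests on a limit of the assay and yields only a floor within the scatter: (the limit of > 50000 nM in this assay, at which 1 of the 4 values shown sits).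

All the aryl groups shown carry only alkyl or halogen substituents, so it remains open whether an amine or a carboxylic acid on this ring would move the number beyond the scatter. As far as these compounds go, it is equally open whether a saturated chain such as n-butyl in place of the aryl group would do so, and whether any change at this nitrogen matters at all in this assay.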